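Halogen swap on the aryl sulfone, compound 3 to compound 4

The compounds below may be only part of what the source reports. "The series", "measured", "known", "first", "only" and "open" are said of these compounds alone.

Compound 3 `O=S(=O)(c1cccc(Cl)c1)c1cn(C2CCCNC2)c2ncccc12` carries a 3-chlorophenyl group and gives 1.3 nM in an assay on HeLa cells for displacement of a labelled ligand from 5-hydroxytryptamine receptor 6 (Homo sapiens); on this read-out lower numbers stand for stronger inhibition and higher numbers for weaker inhibition. Compound 1 `O=S(=O)(c1cccc(Br)c1)c1cn(C2CCNC2)c2ncccc12` gives 1.3 nM and compound 2 `O=S(=O)(c1ccccc1)c1cn(C2CCCNC2)c2ncccc12` gives 4.9 nM; compound 3 is level with compound 1 at the digits shown, the two together being the lowest of the three numbers, and it is furthest from compound 2. Going by the values given here, the single one-place step so far, a 3.8-fold lower number from compound 2 to compound 3 (0.58 log units; beyond the scatter), came from chloro in place of hydrogen on an aromatic carbon.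

Compound 4 `O=S(=O)(c1cccc(Br)c1)c1cn(C2CCCNC2)c2ncccc12` differs from compound 3 by bromo in place of chloro on an aromatic carbon, on an aromatic carbon of a six-membered aromatic ring of carbon only, meta to a large group. Among the compounds with values here, the only step that touches this position is the one from compound 2 to compound 3, which concerned the arrival of a halogen rather than the exchange of one. Compounds 1 and 3 differ in two places and share the same number, which offers no sign that bromo and chloro separate here. For compound 4 the step is therefore expected to be a 1.1-fold lower number from compound 3 to compound 4 (0.03 log units; within the scatter), not beyond the scatter. Compound 4 is expected at 1.2 nM, within 0.5 nM to 3 nM.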

Compound 4, inhibition constant: 3.8 nM
For compound 4 the middle estimate is 3.2-fold (0.50 log units) below the measured one; measured number above the stated range.
By their numbers in this assay, from the lowest: compounds 1 and 3 (each within the scatter of the next); then compounds 4 and 2 (each within the scatter of the next).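

Bromo and chloro are not interchangeable at this place on the piperidin-3-yl compounds: the swap gives a 2.9-fold higher number from compound 3 to compound 4 (0.47 log units; beyond the scatter), while the comparison with the unsubstituted phenyl gives a 1.3-fold lower number from compound 2 to compound 4 (0.11 log units; within the scatter), so the gain seen on adding chloro does not extend to bromo here. With the 3-bromophenyl group held constant, the group on the aromatic nitrogen also counts, with a 2.9-fold higher number from compound 1 to compound 4 (0.47 log units; beyond the scatter), so the effect of this bromo cannot be read apart from that group. No measurement shown accounts for either step.

Open is whether the separation between chloro and bromo also holds on a pyrrolidin-3-yl compound, since only the bromo member of that pair is shown. Also open, as far as these compounds go, is how fluoro, methyl or a nitrile would read at this place, which would show whether chloro stands alone among such groups.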